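A halogen swap on a compound at the assay limit

The compounds below may be only part of what the source reports. "The series", "measured", "known", "first", "only" and "open" are said of these compounds alone.

Compound 1 `Cc1ccc(S(=O)(=O)N[C@@H](CC(=O)NC(C)(C)C)C(=O)NCCNC(=O)c2ccccc2)cc1`: > 11000 nM (a limit)
Compound 2 `Cc1ccc(S(=O)(=O)N[C@@H](CC(=O)NC(C)(C)C)C(=O)NCCNC(=O)c2ccccc2Cl)cc1`: > 11000 nM (a limit)

In an ADME assay on HepG2 cells (Homo sapiens) for cytotoxicity (a lower number here means that less compound is needed, a higher number that more compound is needed for the effect), compound 2 gives > 11000 nM as a limit of the assay and not a number. Compound 1 gives > 11000 nM as a limit too. The measurements so far therefore come to this: the limit of > 11000 nM in this assay, at which 2 of the 2 values shown sit. No true number is yet known for either compound.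

The next compound is compound 3 `Cc1ccc(S(=O)(=O)N[C@@H](CC(=O)NC(C)(C)C)C(=O)NCCNC(=O)c2ccc(F)cc2)cc1`. Its difference from compound 2 is 4-fluorophenyl in place of 2-chlorophenyl on a carbonyl carbon, which means 4-fluorophenyl in place of 2-chlorophenyl on a carbonyl carbon.

Going by the values given here, the only measured step that bears on this is a step that the two limits leave unreadable from compound 1 to compound 2, where chloro took the place of hydrogen on an aromatic carbon. That step has no readable size, so it points in no direction. No step beyond the scatter is therefore expected in this assay, and a reading at the same limit is the likeliest outcome.

The estimated change is a step that the limit leaves unreadable from compound 2 to compound 3 in this case. For compound 3 the expected value is 15000 nM, with an estimated range from 9000 nM to 40000 nM as the likely span.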

Compound 3, half-maximal effective concentration: > 11000 nM
Compound 3: only a limit was reported; the forecaster's own chance of this, stated with the estimate: 85%; the middle value is on the limit's open side.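

Compound 3 gives > 11000 nM in this assay, a limit of the assay and not a number. The steps among compound 1, compound 2 and compound 3 therefore cannot be read: the limit of > 11000 nM in this assay, at which 3 of the 3 values shown sit.

The compounds shown leave open what the true value of each one is, and whether the chloro or fluoro group changes it at all.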